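A few compounds are considered here, and "the series" means these few. Any claim that something is new, unique, unknown or untested is made for them only; others in the source may bear on it.

Measured in a functional assay, read by spectrophotometry, with a stated time of 5 min; a lower number here means a stronger inhibitor, a higher number a weaker inhibitor:
- compound 1 `COc1cc(/C=C/C(=O)C(=Cc2ccc(O)cc2)C(=O)/C=C/c2ccc(O)c(OC)c2)ccc1O` gives 6320 nM
- compound 2 `CCOc1ccc(C=C(C(=O)/C=C/c2ccc(O)c(OC)c2)C(=O)/C=C/c2ccc(O)c(OC)c2)cc1OCC` gives 10000 nM
- compound 3 `CCOc1cc(C=C(C(=O)/C=C/c2ccc(O)c(OCC)c2)C(=O)/C=C/c2ccc(O)c(OCC)c2)ccc1O` gives 5140 nM

Compound 3 stands within the scatter of both compound 1 and compound 2, so these three values do not separate. Compound 4 `CCOc1cc(/C=C/C(=O)C(=Cc2ccccc2)C(=O)/C=C/c2ccc(O)c(OCC)c2)ccc1O` differs from compound 3 by one change: phenyl in place of 3-ethoxy-4-hydroxyphenyl on a double-bonded chain carbon bound to a double-bonded chain carbon. Within the data shown here, the only measured step at this place is a 1.6-fold higher number from compound 1 to compound 2 (0.20 log units; within the scatter), which stays within the scatter, although no measured compound carries a plain phenyl there. On that basis, no step beyond the scatter is expected in this assay. The expected change is a 1.3-fold higher number from compound 3 to compound 4 (0.10 log units; within the scatter). For compound 4 the estimated value is 6500 nM, with an expected range of 2800 nM to 15000 nM.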

Compound 4, half-maximal inhibitory concentration: 20400 nM
Compound 4: middle estimate off by 3.1-fold (0.50 log units), on the low side; the whole stated range lies below it.
By their numbers in this assay, from the lowest: compounds 3, 1 and 2 (each within the scatter of the next); then compound 4.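

In this assay, phenyl in place of 3-ethoxy-4-hydroxyphenyl on a double-bonded chain carbon bound to a double-bonded chain carbon gives a 4.0-fold higher number from compound 3 to compound 4 (0.60 log units; beyond the scatter). Among these compounds, the earlier step at this place, a 1.6-fold higher number from compound 1 to compound 2 (0.20 log units; within the scatter), stayed within the scatter, so this is the first sign that the place responds to the group it carries, with weaker inhibition once the ring has neither hydroxy nor ethoxy. Nothing at hand accounts for this loss.

On these data alone, the change removes hydroxy and ethoxy together, so their separate shares remain open. As far as these compounds go, whether an amine or a carboxylic acid on this ring would restore inhibition also remains open.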